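Adding a Hydroxy Group to a Stomach Inhibition Series

A few compounds are considered here, and "the series" means these few. Any claim that something is new, unique, unknown or untested is made for them only; others in the source may bear on it.

Three measured compounds share one core: compound 1 `CCCCCCc1ccc(-c2cc(=O)c3cc(C(=O)O)ccc3o2)cc1`, compound 2 `COc1ccc(-c2cc(=O)c3cc(C(=O)O)ccc3o2)cc1` and compound 3 `O=C(O)c1ccc2oc(-c3ccc(F)cc3)cc(=O)c2c1`. In a functional assay on the whole organism (stomach) for inhibition, with Rattus norvegicus as the target, at a dose of 80 mg/kg (a higher number here means more inhibition at the dose given (going by the name of the read-out), a lower number less inhibition), compound 1 gives 2%, compound 2 gives 13% and compound 3 gives 21%. Compound 2 sits close to compound 3, since a number 8 percentage points higher from compound 2 to compound 3 (within the scatter), while a number 11 percentage points higher from compound 1 to compound 2 (beyond the scatter) and a number 19 percentage points higher from compound 1 to compound 3 (beyond the scatter) lie beyond the scatter. Compound 4 `COc1ccc(-c2oc3ccc(C(=O)O)cc3c(=O)c2O)cc1` differs from compound 2 by hydroxy in place of hydrogen on an aromatic carbon. For the measured compounds named here, none of the measured steps touches that kind of change; all three swap a hexyl, methoxy or fluoro group elsewhere, so there is no guide, and a step within the scatter is expected. Compound 4 is therefore expected to give 15%, between 0% and 35%, an expected step of a number 2 percentage points higher from compound 2 to compound 4 (within the scatter).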

Compound 4, a percentage reported as inhibition, in the whole organism at one dose (the size of the read-out at that dose, not a potency): 24%
The estimate for compound 4 lay 9 percentage points below the measured number, and the stated range covers the measured number.
By their numbers in this assay, from the lowest: compound 1; then compounds 2, 3 and 4 (each within the scatter of the next, the first and the last beyond it).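

For the compounds shown here, putting a hydroxy group in place of hydrogen on the aromatic carbon two atoms from the ring oxygen gives a number 11 percentage points higher from compound 2 to compound 4 (beyond the scatter) in this assay and so shows that this position, untouched by the earlier steps, can shift the read-out. The step is modest, and it rests on a single pair of compounds. No measurement here bears on why the number rises.

Going by these compounds, it remains open whether an amine or a longer chain at this position would give a similar step. On these data alone, it also remains open whether the hydroxy step would hold with fluoro or hexyl in place of the methoxy group.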